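Swapping the Benzylamino Linker for Sulfur on a Nucleoside

The source may report more compounds than this note shows. Statements on the series, on what has been measured and on what is new or still open speak of the compounds shown alone.

Three nucleosides sharing one core were measured in a functional assay (Homo sapiens) for inhibition of Nucleic Acid, tested at 100 uM; on this read-out lower numbers stand for less inhibition and higher numbers for more inhibition at the one concentration tested (going by the name of the read-out). Compound 1 `OC[C@H]1OC(n2cnc3c(Nc4ccccc4)nccc32)[C@H](O)[C@@H]1O` gives 4%, and compound 2 `CCNc1nccc2c1ncn2C1O[C@H](CO)[C@@H](O)[C@H]1O` gives 4%. Compound 3 `OC[C@H]1OC(n2cnc3c(NCc4ccccc4)nccc32)[C@H](O)[C@@H]1O` gives 32%, the highest of the three numbers: a number 28 percentage points higher from compound 1 to compound 3 (beyond the scatter) and a number 28 percentage points higher from compound 2 to compound 3 (beyond the scatter), whereas no change at the digits printed from compound 1 to compound 2 (within the scatter). Compound 4 `OC[C@H]1OC(n2cnc3c(SCc4ccccc4)nccc32)[C@H](O)[C@@H]1O` differs from compound 3 by benzylsulfanyl in place of benzylamino on an aromatic carbon. Within the data shown here, no measured step exchanges the atom joining the benzyl group to the ring; the two steps that bear on compound 3 replace a different group and leave the nitrogen in place. With nothing to support the sulfur linker, a modest fall is expected, a number 12 percentage points lower from compound 3 to compound 4 (beyond the scatter). Compound 4 is therefore estimated at 20%, in a range from 2% to 40%.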

Compound 4, a percentage reported as inhibition, at one concentration (the size of the read-out at that concentration, not a potency): 30%
Compound 4: middle estimate off by 10 percentage points, on the low side, within the range that was stated.
By their numbers in this assay, from the lowest: compounds 1 and 2 (each within the scatter of the next); then compounds 4 and 3 (each within the scatter of the next).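

In this assay, moving from the benzylamino to the benzylsulfanyl linker gives a number 2 percentage points lower from compound 3 to compound 4 (within the scatter) so this read-out does not separate the two linkers, even though the count of hydrogen-bond donors in the group falls from 1 to 0. Compound 4 also stands clear of the smaller ethylamino and the anilino groups, with a number 26 percentage points higher from compound 2 to compound 4 (beyond the scatter) and a number 26 percentage points higher from compound 1 to compound 4 (beyond the scatter) so the benzyl group goes with the higher numbers whichever of the two linkers carries it. No available evidence accounts for these results. As far as these compounds go, whether a benzyloxy group or a longer chain between the linker and the phenyl ring would keep this level remains open.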